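An aryl amide exchange at the assay limit

The source may hold more compounds than are shown below. What is called first, only, known or untested is meant among the compounds shown, and "the series" means these compounds.

Measured in a functional assay on PC-3 cells (Homo sapiens) for antiproliferative activity, read by MTT assay, with a stated time of 48 h; a higher number here means a weaker inhibitor, a lower number a stronger inhibitor:
- Compound 1 `C=CCN(C)C(=O)c1ccc(C(CC)(CC)c2ccc(OCCC(O)(CC)CC)c(C)c2)n1CC` gives 12800 nM
- Compound 2 `C#CC(C)OC(=O)c1ccc(C(CC)(CC)c2ccc(OCCC(O)(CC)CC)c(C)c2)n1CC` gives 14800 nM
- Compound 3 `CCn1c(C(=O)Nc2ccc(OC(F)(F)F)cc2)ccc1C(CC)(CC)c1ccc(OCCC(O)(CC)CC)c(C)c1` gives > 50000 nM

Compound 3 shows > 50000 nM as a limit of the assay and not as a number. Compound 4 `CCn1c(C(=O)Nc2cccc(C(F)(F)F)c2)ccc1C(CC)(CC)c1ccc(OCCC(O)(CC)CC)c(C)c1` differs from it only on the amide-type nitrogen, where 3-(trifluoromethyl)phenyl stands in place of 4-(trifluoromethoxy)phenyl 3-(trifluoromethyl)phenyl in place of 4-(trifluoromethoxy)phenyl on an amide-type nitrogen and the rest of the structure stays the same. For the measured compounds named here, no measured step makes this exact change. The nearest are the two that bring in (4-(trifluoromethoxy)phenyl)amino on a carbonyl carbon, namely an at least 3.9-fold higher number from compound 1 to compound 3 (0.59 log units; beyond the scatter) and an at least 3.3-fold higher number from compound 2 to compound 3 (0.52 log units; beyond the scatter). By contrast, the exchange without a phenyl group gave a 1.2-fold higher number from compound 1 to compound 2 (0.06 log units; within the scatter). Compound 4 keeps a substituted phenyl group on that nitrogen, so the result of an at least 3.9-fold higher number from compound 1 to compound 3 (0.59 log units; beyond the scatter) is expected to carry over. No step beyond the scatter is expected in this assay, and the estimate is a number no higher from compound 3 to compound 4 (the limit leaves the size open). Compound 4 is estimated at 50000 nM with an expected range of 20000 nM to 100000 nM.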

Compound 4, half-maximal inhibitory concentration: 23800 nM
Beside the measured number, compound 4's estimate is 2.1-fold (0.32 log units) above it, within the range that was stated.
By their numbers in this assay, from the lowest: compounds 1, 2 and 4 (each within the scatter of the next). At a limit, above all of these: compound 3.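

Compound 3 stands at a limit and not at a number: the limit of > 50000 nM in this assay, at which 1 of the 4 values shown sits.

In this assay, as far as these compounds go, 3-(trifluoromethyl)phenyl in place of 4-(trifluoromethoxy)phenyl on the amide-type nitrogen brings a measurable value, with an at least 2.1-fold lower number from compound 3 to compound 4 (0.32 log units; beyond the scatter), and the true size of this step stays open on one side. Compound 4 also remains within the scatter of the two compounds without a phenyl group, with a 1.9-fold higher number from compound 1 to compound 4 (0.27 log units; within the scatter) and a 1.6-fold higher number from compound 2 to compound 4 (0.21 log units; within the scatter), so a substituted phenyl on this nitrogen does not by itself give a reading at the limit.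

The exchange alters both the substituent and its place on the phenyl ring, and the compounds shown cannot separate the two. Also open, from the compounds shown here alone, is how an unsubstituted phenyl, or a phenyl carrying a carboxylic acid or an amine, would read on this nitrogen.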